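A few compounds are considered here, and "the series" means these few. Any claim that something is new, unique, unknown or untested is made for them only; others in the source may bear on it.

In an ADME assay on MT4 cells (Homo sapiens) for cytotoxicity, read by MTT assay, with a stated time of 4 days (on this read-out lower numbers stand for higher toxicity in this test and higher numbers for lower toxicity in this test), the measured compounds gave:

compound 1 `Cc1ccc(-c2c(C)c(-c3ccc(C)c(C)c3)c(C(OC(C)(C)C)C(=O)O)c(C)c2N)cc1C`: 12000 nM
compound 2 `CNC(=O)Nc1c(C)c(C(OC(C)(C)C)C(=O)O)c(-c2ccc(C)c(C)c2)c(C)c1-c1ccc(C)c(C)c1`: 20000 nM
compound 3 `Cc1ccc(-c2c(C)c(-c3ccc(C)c(C)c3)c(C(OC(C)(C)C)C(=O)O)c(C)c2NS(C)(=O)=O)cc1C`: 15000 nM

Compound 3 sits within the scatter of both other compounds: a 1.3-fold higher number from compound 1 to compound 3 (0.10 log units; within the scatter) and a 1.3-fold lower number from compound 2 to compound 3 (0.12 log units; within the scatter). Compound 4 `CNc1c(C)c(C(OC(C)(C)C)C(=O)O)c(-c2ccc(C)c(C)c2)c(C)c1-c1ccc(C)c(C)c1` differs from compound 3 at a single place: methyl in place of methylsulfonyl on a nitrogen on an aromatic ring. Within the data shown here, every measured step so far changes what sits on this same nitrogen, and each stayed within the scatter: a 1.7-fold higher number from compound 1 to compound 2 (0.22 log units; within the scatter) beside the two steps already named. Methyl itself has not been tried at that position, but with hydrogen, methylcarbamoyl and methylsulfonyl all giving much the same read-out, the expected step of a 1.1-fold lower number from compound 3 to compound 4 (0.03 log units; within the scatter) is also small, with no direction beyond the scatter. Compound 4 is therefore estimated at 14000 nM, within a range of 6000 nM to 32000 nM.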

Compound 4, half-maximal cytotoxic concentration: 8800 nM
Compound 4: middle estimate off by 1.6-fold (0.20 log units), on the high side; low and high end bracket the measured number.
By their numbers in this assay, from the lowest: compounds 4, 1, 3 and 2 (each within the scatter of the next, the first and the last beyond it).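

Methyl on this nitrogen gives the first step beyond the scatter, though only against methylcarbamoyl: in this assay the change is a 2.3-fold lower number from compound 2 to compound 4 (0.36 log units; beyond the scatter) and remains modest. Against the other two groups it stays small, at a 1.7-fold lower number from compound 3 to compound 4 (0.23 log units; within the scatter) and a 1.4-fold lower number from compound 1 to compound 4 (0.13 log units; within the scatter), so across these four compounds the read-out moves little when this nitrogen's substituent changes. No evidence here explains the one larger gap.

Still open, on these data alone, is whether a longer chain such as ethyl would follow methyl or move the read-out further. An acetyl group on this nitrogen is equally untested by the compounds shown.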